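The source may hold more compounds than are shown below. What is called first, only, known or untested is meant among the compounds shown, and "the series" means these compounds.

Measured so far:
Compound 1 `Cc1cc(NCc2ccccn2)n2nc(C)c(-c3ccc(F)cc3)c2n1`: in a physicochemical assay for solubility, read by HPLC, using the shake flask method, measured as kinetic solubility, with a stated time of 2 h, at pH 7.4 (on this read-out lower numbers stand for lower solubility and higher numbers for higher solubility), compound 1 gives < 5000 nM, which is a limit of the assay.
Compound 2 `Cc1cc(NCc2ccccn2)n2ncc(-c3ccc(F)cc3)c2n1`: compound 2 gives < 5000 nM, also a limit of the assay.
Compound 3 `Cc1cc(NCc2ccccn2)n2ncc(-c3ccco3)c2n1`: compound 3 gives 48800 nM.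

Compound 1 thus sits at the limit of < 5000 nM in this assay, at which 2 of the 3 values shown sit, and no exact number is known for it. Compound 4 `Cc1cc(NCc2ccccn2)n2nc(C)c(-c3cccnc3F)c2n1` differs from compound 1 by 2-fluoropyridin-3-yl in place of 4-fluorophenyl on an aromatic carbon. Of the measured steps, a step that the two limits leave unreadable from compound 1 to compound 2 shows no readable size. The step of an at least 9.7-fold higher number from compound 2 to compound 3 (0.98 log units; beyond the scatter) swapped the same 4-fluorophenyl for a ring carrying a hetero atom and gave an at least modest rise. Compound 4 likewise brings in a ring with 1 hetero atom, so in this assay a rise of similar order is expected, an at least 3.0-fold higher number from compound 1 to compound 4 (0.47 log units; beyond the scatter). Compound 4 is therefore estimated at 15000 nM, expected to lie between 3000 nM and 60000 nM.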

Compound 4, solubility: < 5000 nM
Compound 4: a limit, no number (the forecaster's own chance of this, stated with the estimate: 30%); middle value at least 3.0-fold (0.47 log units) away from the limit.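

In this assay compound 4 gives < 5000 nM, which is a limit and not a number. Among the compounds shown here, compound 1 stands at the same limit, so no step between the two can be read: the limit of < 5000 nM in this assay, at which 3 of the 4 values shown sit. As far as these compounds go, whether 2-fluoropyridin-3-yl in place of 4-fluorophenyl changes the read-out at all stays open.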